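A few compounds are considered here, and "the series" means these few. Any claim that something is new, unique, unknown or untested is made for them only; others in the source may bear on it.

Of the compounds shown here, three built on one shared core have been measured in a functional assay on NCI-H3122 cells (Homo sapiens) for antiproliferative activity, read by MTT assay, with a stated time of 48 h; a higher number here means a weaker inhibitor, a lower number a stronger inhibitor. Compound 1 `COc1cccc(CNC(=O)c2cccc(C(C)Oc3ccnc(Nc4cnn(C)c4)c3)c2)c1` gives in this assay only the limit > 100000 nM, which is a boundary of the measurement rather than a number. Compound 2 `COc1ccc(CNC(=O)c2cccc(C(C)Oc3ccnc(Nc4cnn(C)c4)c3)c2)cc1OC` gives 38500 nM in this assay, and compound 3 `COc1cc(CNC(=O)c2cccc(C(C)Oc3ccnc(Nc4cnn(C)c4)c3)c2)cc(OC)c1OC` gives 29000 nM. The step of an at least 2.5-fold lower number from compound 1 to compound 2 (0.41 log units; beyond the scatter) and the step of an at least 3.4-fold lower number from compound 1 to compound 3 (0.53 log units; beyond the scatter) both move the number downward, toward stronger inhibition, while the step of a 1.3-fold lower number from compound 2 to compound 3 (0.12 log units; within the scatter) is too small to count. Compound 3 therefore has the lowest number of the two that were measured as numbers, but it sits so close to compound 2 that no order between them can be claimed.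

Compound 4 `CC(Oc1ccnc(Nc2cnn(C)c2)c1)c1cccc(C(=O)NCc2cc(F)cc(F)c2)c1` is not yet measured. Its change from compound 3 is 3,5-difluorophenyl in place of 3,4,5-trimethoxyphenyl on a saturated chain carbon bound to an amide-type nitrogen. For the measured compounds named here, the steps that bear on it run the opposite way: adding methoxy groups lowered the number in the steps from compound 1, so removing all three and putting in two fluorines instead is expected to raise it, perhaps back toward the limit seen for compound 1. The expected step of a 2.4-fold higher number from compound 3 to compound 4 (0.38 log units; beyond the scatter) is a rise in the number. Compound 4 is accordingly estimated at about 70000 nM, within a range from 25000 nM to 200000 nM.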

Compound 4, half-maximal inhibitory concentration: 7600 nM
The estimate for compound 4 lay 9.2-fold (0.96 log units) above the measured number, outside the stated range (below it).
By their numbers in this assay, from the lowest: compound 4; then compounds 3 and 2 (each within the scatter of the next). At a limit, above all of these: compound 1.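

On the saturated chain carbon bound to an amide-type nitrogen, methoxy groups on the phenyl ring turn out not to be needed for a lower number in this assay: putting 3,5-difluorophenyl there gives a 3.8-fold lower number from compound 3 to compound 4 (0.58 log units; beyond the scatter) and a 5.1-fold lower number from compound 2 to compound 4 (0.70 log units; beyond the scatter). For the compounds shown here, compound 4 carries no methoxy group at all, so it goes against the reading of the earlier steps that more methoxy simply means a lower number, and the same kind of change also gives an at least 13-fold lower number from compound 1 to compound 4 (1.11 log units; beyond the scatter). That last step is only a minimum because compound 1 stands at a limit of the assay and not at a number: the limit of > 100000 nM in this assay, at which 1 of the 4 values shown sits.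

As far as these compounds go, the change removes the methoxy groups and brings in the fluorines at once, so it stays open whether the fluorines themselves matter or only the loss of the methoxy groups, a question that an unsubstituted phenyl ring would help to settle. Also open, from the compounds shown here alone, is how the number would respond to other groups on this ring, such as chlorine, a nitrile, an amine or a carboxylic acid.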